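Removing the Ring Methyl from a Weak Antagonist

The compounds below may be only part of what the source reports. "The series", "measured", "known", "first", "only" and "open" are said of these compounds alone.

Compound 1 `CN1CC(c2ccc(C(F)(F)F)cc2)(C(O)c2ccccn2)C1` carries a methyl on the nitrogen of its small ring. In an assay on HEK293 cells for antagonist activity at transient receptor potential cation channel subfamily V member 3 (Homo sapiens), read by FLIPR and calcium flux (on this read-out lower numbers stand for stronger inhibition and higher numbers for weaker inhibition), compound 1 gives 6630 nM, the highest of the two numbers measured here. Compound 2 `O[C@H](c1ccccn1)[C@]1(c2cccc(OC(F)(F)F)c2)C[C@@H](O)C1`, built on a different core with different substituents, gives 80 nM in this assay, a far lower number; no single-point change joins the two structures, so their values can only be set side by side. Compound 3 `OC(c1ccccn1)C1(c2ccc(C(F)(F)F)cc2)CNC1` is compound 1 with hydrogen in place of methyl on an amine nitrogen in a ring: the methyl leaves and a hydrogen enters on the amine nitrogen of the four-membered non-aromatic ring with 1 nitrogen. Nothing measured here shows what such a change does, so only a small step is expected, a 1.7-fold lower number from compound 1 to compound 3 (0.22 log units; within the scatter), a mild move toward a lower number that sits near the edge of the scatter. Compound 3 is therefore estimated at 4000 nM, with a range from 1000 nM to 15000 nM.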

Compound 3, antagonist equilibrium constant: 6680 nM
Compound 3: middle estimate off by 1.7-fold (0.22 log units), on the low side; measured number inside the range.
By their numbers in this assay, from the lowest: compound 2; then compounds 1 and 3 (each within the scatter of the next).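

Taking the methyl off the amine nitrogen of the four-membered non-aromatic ring with 1 nitrogen gives a 1.0-fold higher number from compound 1 to compound 3 (0.00 log units; within the scatter) in this assay, so the two values cannot be told apart. Going by these compounds alone, this is the first direct reading at this position: on the core of compound 1, a methyl and a hydrogen on this nitrogen give the same result within the scatter of repeated measurements. No measurement beyond these values bears on this result.

A single pair cannot show whether the nitrogen would be equally indifferent to a longer chain such as propyl, to a benzyl group or to an acetyl group. It also leaves open whether the same swap would give the same result with other groups elsewhere on the core.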